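A few compounds are considered here, and "the series" means these few. Any claim that something is new, unique, unknown or untested is made for them only; others in the source may bear on it.

Measured so far:
Compound 1 `CCN1CCc2c(c(C)nn2C(=O)Nc2c(C)cccc2C)C1` — 60.5%
Compound 2 `CCN1CCc2c(c(C(C)(C)C)nn2C(=O)Nc2ccc(Br)cc2)C1` — 72.8%

In a functional assay on the whole organism (strain Swiss albino) for inhibition, with Mus musculus as the target, in the writhing test, with a stated time of 30 min, at a dose of 100 mg/kg (a lower number here means less inhibition, a higher number more inhibition at the dose given (going by the name of the read-out)), compound 2 gives 72.8%, the higher of the two numbers, and the nearest value, from compound 1 at 60.5%, lies beyond the scatter. Compound 3 `CCN1CCc2c(c(C(C)(C)C)nn2C(=O)Nc2c(C)cccc2C)C1` is not yet measured. It differs from compound 2 by 2,6-dimethylphenyl in place of 4-bromophenyl on an amide-type nitrogen. Within the data shown here, no step between measured compounds covers this change; compound 1 already carries the entering group, and its value in this assay sits lower. Compound 3 is therefore expected to fall by a number 8.8 percentage points lower from compound 2 to compound 3 (within the scatter), a step that may stay within the scatter. The value of compound 3 in this assay is estimated at 64%, between 50% and 78%.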

Compound 3, a percentage reported as inhibition, in the whole organism at one dose (the size of the read-out at that dose, not a potency): 73.7%
Beside the measured number, compound 3's estimate is 9.7 percentage points below it; the measured number falls inside the stated range.
By their numbers in this assay, from the lowest: compound 1; then compounds 2 and 3 (each within the scatter of the next).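

In this assay, 2,6-dimethylphenyl in place of 4-bromophenyl on an amide-type nitrogen gives a number 0.9 percentage points higher from compound 2 to compound 3 (within the scatter), so with tert-butyl on the aromatic carbon the two groups are not told apart. Tert-butyl in place of methyl on an aromatic carbon gives a number 13.2 percentage points higher from compound 1 to compound 3 (beyond the scatter), the first change in one place seen to exceed the scatter. Nothing measured here explains either step. From the compounds shown here alone, whether tert-butyl gives a similar step with 4-bromophenyl on the amide-type nitrogen stays open. Also open, going by these compounds, is how an amine or a carboxylic acid on that phenyl ring would affect the read-out.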